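This account rests on a few compounds, and the source may have more. Where it says the series, first, only, none or still open, it means among the compounds named here.

Measured compounds:
compound 1 `COc1ccc2[nH]c(C(=O)N3CC(=O)N(Cc4ccccc4)[C@@H](COC(C)(C)C)C3)cc2c1` – 65500 nM
compound 2 `COc1ccc2[nH]c(C(=O)N3CC(=O)N(Cc4ccccc4)[C@@H](COc4ccc(F)cc4)C3)cc2c1` – 17500 nM
compound 3 `COc1ccc2[nH]c(C(=O)N3CC(=O)N(Cc4ccccc4)[C@@H](CN4CC5CCCC5C4)C3)cc2c1` – 20700 nM

In a physicochemical assay for solubility, read by spectrophotometry, in phosphate buffer, with a stated time of 2 h, at pH 7.4 (on this read-out lower numbers stand for lower solubility and higher numbers for higher solubility), compound 3 gives 20700 nM, the second highest of the three numbers. Its nearest neighbour is compound 2, which gives 17500 nM, a gap that lies within the scatter a 1.2-fold higher number from compound 2 to compound 3 (0.07 log units; within the scatter). The furthest is compound 1, which gives 65500 nM a 3.2-fold lower number from compound 1 to compound 3 (0.50 log units; beyond the scatter).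

Compound 4 `COc1ccc2[nH]c(C(=O)N3CC(=O)N(Cc4ccccc4)[C@@H](CN4CCn5cccc5C4)C3)cc2c1` has not yet been measured in this assay. It differs from compound 3 by a group of 9 heavy atoms (7 carbon, 2 nitrogen; one five-membered aromatic ring with 1 hetero atom, one six-membered non-aromatic ring with 2 hetero atoms) in place of a group of 8 heavy atoms (7 carbon, 1 nitrogen; one five-membered non-aromatic ring of carbon only, one five-membered non-aromatic ring with 1 hetero atom), on a saturated chain carbon bound to a saturated ring carbon. Going by the values given here, two measured steps touch the same position. The step of a 3.2-fold lower number from compound 1 to compound 3 (0.50 log units; beyond the scatter) is modest, and the step of a 1.2-fold higher number from compound 2 to compound 3 (0.07 log units; within the scatter) is within the scatter, so the swaps made so far at this position have moved the number by a modest amount at most. On that basis a step of no more than modest size is expected for compound 4, with no clear direction, and most likely nothing beyond the scatter a 1.0-fold lower number from compound 3 to compound 4 (0.01 log units; within the scatter). Compound 4 is therefore estimated at 20000 nM, within a range of 8000 nM to 50000 nM.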

Compound 4, solubility: 29700 nM
Beside the measured number, compound 4's estimate is 1.5-fold (0.17 log units) below it; the range from low to high includes it.
By their numbers in this assay, from the lowest: compounds 2, 3 and 4 (each within the scatter of the next); then compound 1.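

In this assay, the position on a saturated chain carbon bound to a saturated ring carbon now takes a third ring-bearing group, and it stays with the other two: the change gives a 1.4-fold higher number from compound 3 to compound 4 (0.16 log units; within the scatter), and against the 4-fluorophenyl ether it gives a 1.7-fold higher number from compound 2 to compound 4 (0.23 log units; within the scatter). Only the ring-free tert-butyl ether stays apart, with a 2.2-fold lower number from compound 1 to compound 4 (0.34 log units; beyond the scatter), so among the four compounds the three with rings at this position form one group, and none goes against this. No measurement at hand accounts for these steps.

The compounds shown leave open whether a carboxylic acid or an open-chain amine at this position would fall with the ring-bearing groups. They also leave open whether another ring-free ether, such as a methyl ether, would stand with compound 1.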